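A few compounds are considered here, and "the series" means these few. Any claim that something is new, unique, unknown or untested is made for them only; others in the source may bear on it.

Measured so far in a functional assay on cells for antagonist activity at prostaglandin E2 receptor EP1 subtype (Rattus norvegicus), read by fluorescence and calcium flux, with a stated time of 60 s; on this read-out lower numbers stand for stronger inhibition and higher numbers for weaker inhibition:
Compound 1 `O=C(O)c1cccc(Cc2c(-c3ccccc3)nn3cc(Br)ccc23)n1` gives 11 nM.
Compound 2 `O=C(O)c1cccc(Cc2c(-c3ccccc3)nn3cc(C4CC4)ccc23)n1` gives 190 nM.
Compound 3 `O=C(O)c1cccc(Cc2c(-c3ccsc3)nn3cc(Cl)ccc23)n1` gives 110 nM.

Among these three numbers compound 3 stands second highest. Its nearest neighbour is compound 2, whose number lies within the usual scatter of it, so the two cannot be ranked against each other. Compound 1 is furthest away, with a number beyond the scatter lower, so compound 1 inhibits more strongly than compound 3 in this assay.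

Compound 4 `O=C(O)c1cccc(Cc2c(N3CCCCC3)nn3cc(Cl)ccc23)n1` differs from compound 3 in one place: piperidin-1-yl in place of thiophen-3-yl on an aromatic carbon. The changed group sits on an aromatic carbon of the five-membered aromatic ring with two nitrogens, part of the fused two-ring core.

Among the measured compounds shown here, only one measured step exists, a 17-fold higher number from compound 1 to compound 2 (1.24 log units; beyond the scatter), and it concerns a different place of the shared core, where bromo becomes cyclopropyl. For the measured compounds named here, it shows that a small swap on this core can move the number a great deal, but no measured step touches the aromatic group exchanged here, so the direction of the change is open. Compound 4 is therefore expected, with wide uncertainty, to give about 300 nM in this assay, with a range from 60 nM to 1500 nM. The expected step is a 2.7-fold higher number from compound 3 to compound 4 (0.44 log units; beyond the scatter), leaning toward weaker inhibition, though the range reaches into stronger inhibition as well.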

Compound 4, half-maximal inhibitory concentration: 79 nM
For compound 4 the middle estimate is 3.8-fold (0.58 log units) above the measured one, within the range that was stated.
By their numbers in this assay, from the lowest: compound 1; then compounds 4, 3 and 2 (each within the scatter of the next, the first and the last beyond it).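

Exchanging the ring at this position gives a 1.4-fold lower number from compound 3 to compound 4 (0.14 log units; within the scatter) in this assay, so the two compounds cannot be ranked against each other. At this aromatic carbon, then, a six-membered non-aromatic ring attached through its nitrogen reads the same as a five-membered aromatic ring attached through carbon, so in this pair an aromatic ring at this place is not needed to keep the number where it is. Nothing measured here explains why these two different rings read alike.

On these data alone, whether the position accepts other groups remains open: a morpholin-4-yl ring, or an open-chain amine such as diethylamino, might behave quite differently. Also unresolved is whether piperidin-1-yl would hold up equally well with bromo in place of chloro on the shared core.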